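Taking One Chloro Group Off Compound 3

A few compounds are considered here, and "the series" means these few. Any claim that something is new, unique, unknown or untested is made for them only; others in the source may bear on it.

Of the compounds shown here, three that share one core have been tested in an ADME assay on Vero cells (Chlorocebus sabaeus) for cytotoxicity, read by CellTiter-Glo and ATP content, with a stated time of 72 h; a lower number here means that less compound is tolerated, a higher number that more compound is tolerated. Compound 1 (`Nc1c(C2=NCCN2)cnn1-c1ccc(Cl)cc1`) gives > 500000 nM, which is a limit of the assay and not a number. Compound 2 (`Nc1c(C2=NCCCN2)cnn1-c1ccccc1`) gives > 500000 nM, again a limit. Compound 3 (`Nc1c(C2=NCCCN2)cnn1-c1ccc(Cl)c(Cl)c1`) gives > 500000 nM, also a limit. Compound 3 thus stands at the limit of > 500000 nM in this assay, at which 3 of the 3 values shown sit.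

Compound 4 (`Nc1c(C2=NCCCN2)cnn1-c1ccc(Cl)cc1`) differs from compound 3 in one place: hydrogen in place of chloro on an aromatic carbon. Among the measured compounds shown here, no measured pair shows this change on its own, so the expectation is a loose one. In this assay, no shift beyond the usual scatter is expected, in either direction. The estimated change is a number no higher from compound 3 to compound 4 (the limit leaves the size open). The expectation rests on compound 2, which has no chloro group and still gives > 500000 nM, a limit. Compound 4 is estimated at 500000 nM, with an expected range of 250000 nM to 1000000 nM, and will most likely be reported only as a limit.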

Compound 4, half-maximal cytotoxic concentration: > 500000 nM
Compound 4 ended at the assay's limit; the forecaster's own chance of this, stated with the estimate: 85%; the middle value sits exactly at the limit.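

No step from compound 1, compound 2 or compound 3 to compound 4 can be read, because all four compounds give a limit of the assay and not a number: the limit of > 500000 nM in this assay, at which 4 of the 4 values shown sit.

The compounds shown leave open how much of each compound the cells tolerate, and whether the chloro groups or the ring change in the group on the shared core alter that.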